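Removing a Carbamate in Two Related Anilide Series

The source may hold more compounds than are shown below. What is called first, only, known or untested is meant among the compounds shown, and "the series" means these compounds.

Measured compounds:
compound 1 `CC(C)[C@H](NC(=O)c1cc(Cl)ccc1OCCCCNC(=O)OC(C)(C)C)C(=O)Nc1ccc([N+](=O)[O-])cc1Cl` gives > 10000 nM in a functional assay on MDA-MB-231 cells (Homo sapiens) for inhibition, read by MTT assay, with a stated time of 72 h (a higher number here means a weaker inhibitor, a lower number a stronger inhibitor), which is a limit of the assay, not a number.
compound 2 `CC(C)[C@H](NC(=O)c1cc(Cl)ccc1OCCCCN)C(=O)Nc1ccc([N+](=O)[O-])cc1Cl` gives 5590 nM in this assay.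
compound 3 `CC(C)C[C@H](NC(=O)c1cc(Cl)ccc1OCCNC(=O)OC(C)(C)C)C(=O)Nc1ccc([N+](=O)[O-])cc1Cl` gives > 10000 nM in this assay, which is again a limit of the assay.

The move from compound 1 to compound 2 is hydrogen in place of tert-butoxycarbonyl on an amine nitrogen. It made an at least 1.7-fold lower number from compound 1 to compound 2 (0.25 log units; that floor lies within the scatter), with compound 1 sitting at the limit of > 10000 nM in this assay, at which 2 of the 3 values shown sit. Compound 4 `CC(C)C[C@H](NC(=O)c1cc(Cl)ccc1OCCN)C(=O)Nc1ccc([N+](=O)[O-])cc1Cl` is not yet measured. Its difference from compound 3 is hydrogen in place of tert-butoxycarbonyl on an amine nitrogen, the same change at the same kind of place as before. How the core of compound 3 differs from that of compound 1 is not broken down here. Among the compounds with values here, the only guide is the earlier step, and the step from compound 3 to compound 4 is expected to be of similar size, an at least 1.6-fold lower number from compound 3 to compound 4 (0.22 log units; that floor lies within the scatter), because compound 2 reached 5590 nM after the same change. Compound 4 is therefore estimated at 6000 nM in this assay, in the range 2500 nM to 15000 nM.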

Compound 4, half-maximal inhibitory concentration: > 10000 nM
Compound 4 was reported as a limit; the forecaster's own chance of this, stated with the estimate: 35%; middle value at least 1.6-fold (0.22 log units) from the limit.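

In this assay compound 4 gives > 10000 nM, which is a limit of the assay and not a number. Compound 3 also stands at a limit, so no step can be read between the two. The compounds shown leave open how far compound 3 and compound 4 lie beyond that limit, and whether they differ at all.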